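The compounds below may be only part of what the source reports. "The series", "measured", "known", "first", "only" and "open" are said of these compounds alone.

Three compounds have been measured in a functional assay (aorta) for antagonist activity, with Oryctolagus cuniculus as the target; on this read-out higher numbers stand for weaker inhibition and lower numbers for stronger inhibition:
compound 1, `CCCCc1ccc(CNCc2ccccc2)c(=O)n1Cc1ccc(-c2ccccc2-c2nn[nH]n2)cc1`, gives 1 nM
compound 2, `CCCCc1ccc(CNC(=O)N(C)C)c(=O)n1Cc1ccc(-c2ccccc2-c2nn[nH]n2)cc1`, gives 2 nM
compound 3, `CCCCc1ccc(CNS(=O)(=O)c2ccccc2)c(=O)n1Cc1ccc(-c2ccccc2-c2nn[nH]n2)cc1`, gives 7 nM

Compound 3 stands at the highest of the three numbers: the steps of a 7.0-fold higher number from compound 1 to compound 3 (0.85 log units; beyond the scatter) and a 3.5-fold higher number from compound 2 to compound 3 (0.54 log units; beyond the scatter) both lie beyond the scatter, whereas a 2.0-fold higher number from compound 1 to compound 2 (0.30 log units; within the scatter) does not. Compound 4, `CCCCc1ccc(CNS(C)(=O)=O)c(=O)n1Cc1ccc(-c2ccccc2-c2nn[nH]n2)cc1`, has not yet been measured; it differs from compound 3 by methyl in place of phenyl on a sulfonyl sulfur. For the measured compounds named here, no measured step alters the group on the sulfonyl sulfur itself. The two steps that reach compound 3 exchange the whole substituent on the amine nitrogen, and both of those were modest in size. Nothing shown therefore points to a large movement in this assay in either direction, and a step within or close to the scatter is the expectation. Compound 4 is expected to give about 10 nM, with a range from 3 nM to 35 nM. The step of a 1.4-fold higher number from compound 3 to compound 4 (0.15 log units; within the scatter) is thus estimated to remain small.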

Compound 4, half-maximal inhibitory concentration: 2 nM
The estimate for compound 4 lay 5.0-fold (0.70 log units) above the measured number; the measured number lies below the stated range.
By their numbers in this assay, from the lowest: compounds 1, 2 and 4 (each within the scatter of the next); then compound 3.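

The group on the sulfonyl sulfur proves to matter in this assay, where methyl in place of phenyl gives a 3.5-fold lower number from compound 3 to compound 4 (0.54 log units; beyond the scatter) and so moves the number beyond the scatter. Methylsulfonyl on the amine nitrogen also reads like dimethylcarbamoyl, with no change at the digits printed from compound 2 to compound 4 (within the scatter) as the step, and like benzyl, with a 2.0-fold higher number from compound 1 to compound 4 (0.30 log units; within the scatter) as the step, so among these four it is phenylsulfonyl, not sulfonyl as such, that stands apart. Nothing available bears on why the number moves with this change.

Going by these compounds, whether an ethyl or a cyclopropyl group on the sulfonyl sulfur would read like methyl or like phenyl remains open. So does whether a phenyl ring carrying a fluorine or a carboxylic acid would shift the number on this sulfur.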